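A few compounds are considered here, and "the series" means these few. Any claim that something is new, unique, unknown or untested is made for them only; others in the source may bear on it.

Compound 1 `Cc1ccc2cc(C(C)N(Cc3ccc(F)cc3)Cc3ccc(C(C)C)cc3)c(=O)[nH]c2c1` — in a toxicity assay on MDCK cells (Canis lupus familiaris) for cytotoxicity, read by crystal violet staining, with a stated time of 48 h (a lower number here means that less compound is tolerated, a higher number that more compound is tolerated), compound 1 gives > 33000 nM, a limit of the assay rather than a number.
Compound 2 `Cc1ccc2cc(CN(Cc3ccc(F)cc3)Cc3ccc(C(C)C)cc3)c(=O)[nH]c2c1` — in this assay compound 2 gives > 33000 nM, again a limit.
Compound 3 `Cc1ccc2[nH]c(=O)c(CN(Cc3ccc(F)cc3)Cc3ccc(C(C)(C)C)cc3)cc2c1` — in this assay compound 3 gives > 27000 nM, also a limit.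

All three measured compounds stop at a limit in this assay: two at the limit of > 33000 nM in this assay, at which 2 of the 3 values shown sit, and one at the limit of > 27000 nM in this assay, at which 1 of the 3 values shown sits. The change from compound 2 to compound 1 is methyl in place of hydrogen on a saturated chain carbon bound to an amine nitrogen and an aromatic carbon, and it yields a step that the two limits leave unreadable from compound 2 to compound 1. How the core of compound 3 differs from that of compound 2 is not broken down here.

Compound 4 `CCc1ccc2[nH]c(=O)c(CN(Cc3ccc(F)cc3)Cc3ccc(C(C)(C)C)cc3)cc2c1` is not yet measured; it arises from compound 3 by methyl in place of hydrogen on a saturated chain carbon bound to an aromatic carbon. This is the same kind of change as that from compound 2 to compound 1, but not the same: there the saturated chain carbon taking the methyl is bound to an amine nitrogen and an aromatic carbon, here to an aromatic carbon only.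

Because compound 3 sits at the limit of > 27000 nM in this assay, at which 1 of the 3 values shown sits, compound 4 is expected to remain at a limit as well, the expected step being a step that the limit leaves unreadable from compound 3 to compound 4. Compound 4 is estimated at 40000 nM, between 20000 nM and 100000 nM.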

Compound 4, half-maximal cytotoxic concentration: > 33000 nM
Compound 4 gave a limit, no number; the forecaster's own chance of this, stated with the estimate: 85%; the middle value does not contradict the limit.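

Compound 3 and compound 4 both stop at a limit in this assay, and the step between them cannot be read. The compounds shown leave open at what concentration any of them would reach the half-maximal cytotoxic read-out.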